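A few compounds are considered here, and "the series" means these few. Any claim that something is new, unique, unknown or untested is made for them only; others in the source may bear on it.

Series values in a functional assay on BGC-823 cells (Homo sapiens) for antiproliferative activity, read by MTT assay, with a stated time of 48 h; a lower number here means a stronger inhibitor, a higher number a weaker inhibitor:

- compound 1 `Fc1ccccc1CSc1nnc(-c2cnccn2)o1`: 18200 nM
- compound 2 `Clc1cccc(CSc2nnc(-c3cnccn3)n2-c2ccccc2)c1`: 20300 nM

Compound 2 stands level with compound 1 in this assay: compound 2 gives 20300 nM and compound 1 gives 18200 nM, and these two values lie within the scatter of each other. The two compounds differ in more than one place, so they give no measure of what a single structural change does.

The next compound to test is compound 3 `Clc1ccc(CSc2nnc(-c3cnccn3)n2-c2ccccc2)cc1`. It has 4-chlorophenyl in place of 3-chlorophenyl on a saturated chain carbon bound to a sulfur, the same atoms joined differently: 4-chlorophenyl in place of 3-chlorophenyl on a saturated chain carbon bound to a sulfur.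

Within the data shown here, no measured pair shows the size of a change of this kind, so the expectation rests on compound 2 at 20300 nM. No shift beyond the scatter is expected in this assay, and no direction can be argued from the data. The estimate amounts to an expected 1.1-fold lower number from compound 2 to compound 3 (0.05 log units; within the scatter). For compound 3 the estimated value is 18000 nM, with an expected range of 8000 nM to 40000 nM.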

Compound 3, half-maximal inhibitory concentration: 27700 nM
Compound 3: middle estimate off by 1.5-fold (0.19 log units), on the low side; measured number inside the range.
By their numbers in this assay, from the lowest: compounds 1, 2 and 3 (each within the scatter of the next).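

In this assay, among these compounds, the exchange of 3-chlorophenyl for 4-chlorophenyl on a saturated chain carbon bound to a sulfur gives the first single-place reading (a 1.4-fold higher number from compound 2 to compound 3 (0.13 log units; within the scatter)). For this one pair, the shift from 3-chlorobenzyl to 4-chlorobenzyl therefore leaves the two compounds level, with compound 2 at 20300 nM and compound 3 at 27700 nM, and a single pair sets no trend for other groups at this position. No measured property of these compounds bears on the result, so the data give no account of it.

Still open, as far as these compounds go, is whether a carboxylic acid or an amine in place of the chlorine, or a longer chain in place of the chlorobenzyl group on the sulfur, would give a step beyond the scatter in this assay. The contribution of the rest of the structure also remains unread, as compound 1 differs from compound 2 and from compound 3 in more than one place.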